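Alkyne-tethered side chains on a shared core

The source may report more compounds than this note shows. Statements on the series, on what has been measured and on what is new or still open speak of the compounds shown alone.

Measured so far:
compound 1, `CC1(CC#Cc2c(Cl)c3c(Cl)cc(C(N)=O)nc3n2[C@H]2CCCNC2)COC1`: 289 nM
compound 2, `NC(=O)c1cc(Cl)c2c(Cl)c(C#CC3COCCO3)n([C@H]3CCCNC3)c2n1`: 77 nM; 203 nM (2 entries)
compound 3, `NC(=O)c1cc(Cl)c2c(Cl)c(C#CC3CCCO3)n([C@H]3CCCNC3)c2n1`: 223 nM; 91 nM (2 entries)

All three share one core and differ only in the group carried on the saturated chain carbon bound to the triple-bonded carbon. Within the data shown here, in a functional assay on KG-1 cells (Homo sapiens) for antiproliferative activity (a higher number here means that more compound is needed for the effect, a lower number that less compound is needed), compound 1 gives 289 nM; this is its only single number, two further entries having yielded none. Compound 2 and compound 3 each have repeated entries (the several entries of compound 2 in this assay, 77 nM; 203 nM (2 entries); (the several entries of compound 3 in this assay, 223 nM; 91 nM (2 entries))), and the spread within each pair is wide enough that none of the three stands apart from the others.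

Compound 4, `CC(C)(CC#Cc1c(Cl)c2c(Cl)cc(C(N)=O)nc2n1[C@H]1CCCNC1)C(N)=O`, is not yet measured. It differs from compound 1 by 1-carbamoyl-1-methylethyl in place of 3-methyloxetan-3-yl on a saturated chain carbon bound to a triple-bonded carbon. Among the measured compounds shown here, no measured pair shows this kind of exchange, so nothing here sets its size. Given how close the three measured compounds sit to one another, the step from compound 1 to compound 4 in this assay is expected to be small and without a clear direction, a 1.2-fold lower number from compound 1 to compound 4 (0.08 log units; within the scatter), that is, within the usual scatter. Compound 4 is therefore expected to give about 240 nM in this assay, with a range from 80 nM to 750 nM.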

Compound 4, half-maximal effective concentration: 269 nM
Compound 4: middle estimate off by 1.1-fold (0.05 log units), on the low side, within the range that was stated.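

In this assay, among these compounds, 1-carbamoyl-1-methylethyl in place of 3-methyloxetan-3-yl on a saturated chain carbon bound to a triple-bonded carbon gives a 1.1-fold lower number from compound 1 to compound 4 (0.03 log units; within the scatter), and this is the first step that can be read directly from a single exchange. The earlier compounds shown here all carried a ring in this side chain and no hydrogen-bond donor in it, so they could not show that an open group with a donor leaves the number within the scatter of the ring-bearing group of compound 1. This reading rests on a step that is small compared with how far repeat entries of a related compound lie apart: the several entries of compound 2 in this assay, 77 nM; 203 nM (2 entries)

On these data alone, whether a carboxylic acid in place of the carbamoyl group, an amine at the same carbon, or a longer chain between the triple-bonded carbon and the carbamoyl group would keep the number in the same range remains open. The compounds shown contain no step beyond the scatter, so how much change this position can take before the antiproliferative effect shifts is still undefined.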